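The source may hold more compounds than are shown below. What is called first, only, known or untested is meant among the compounds shown, and "the series" means these compounds.

Three linear compounds have been tested so far in a functional assay on L1210 cells (Mus musculus) for inhibition, with a stated time of 48 h (a higher number here means a weaker inhibitor, a lower number a stronger inhibitor), and none gave a readable potency. Compound 1 (`CCCNCCCNCCCN`) reached only a limit, > 100000 nM. Compound 2 (`CCCNCCCNCCCNCCC`) also reached only a limit, > 100000 nM. On these data alone, compound 3 (`CCCNCCCCNCCCN`), the starting point here, likewise stands at a limit, > 100000 nM, so its true position is unknown and it cannot be ranked against the other two. Across the series, the record amounts to the limit of > 100000 nM in this assay, at which 3 of the 3 values shown sit.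

Compound 4 (`CCCNCCCCNCCCNCCC`) differs from compound 3 in one place: propyl in place of hydrogen on an amine nitrogen. This is propyl in place of hydrogen on an amine nitrogen. The same replacement has been measured once, as a step that the two limits leave unreadable from compound 1 to compound 2. That step has no readable size or direction, so it offers no shift to carry over, though it shows that the replacement did not bring compound 2 to a measurable value in this assay. No step beyond the usual scatter is therefore expected, and a further limit is the likeliest result. The expected step, a number no higher from compound 3 to compound 4 (the limit leaves the size open), is only a rough estimate with no direction behind it. For compound 4 the estimated value is 100000 nM, with an expected range from 30000 nM to 300000 nM.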

Compound 4, half-maximal inhibitory concentration: > 100000 nM
Compound 4 gave a limit, no number; the forecaster's own chance of this, stated with the estimate: 80%; the middle value sits exactly at the limit.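

In this assay compound 4 gave only a limit, > 100000 nM. Its steps from compound 1, compound 2 and compound 3 therefore cannot be read. The compounds shown leave open whether any of these linear compounds, with or without the added propyl, reaches a measurable potency, and the record so far reads: the limit of > 100000 nM in this assay, at which 4 of the 4 values shown sit.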